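The source may report more compounds than this note shows. Statements on the series, on what has been measured and on what is new or still open speak of the compounds shown alone.

Compound 1, `Cc1ccc(S(=O)(=O)/C(=C/c2ccc(Oc3ccccc3)cc2)C(=O)c2ccc(Cl)cc2)cc1`: 1000 nM
Compound 2, `Cc1ccc(S(=O)(=O)/C(=C/c2ccc(N(C)C)cc2)C(=O)c2ccc(Cl)cc2)cc1`: > 100000 nM
Compound 3, `CC(=O)Oc1ccc(/C=C(\C(=O)c2ccc(Cl)cc2)S(=O)(=O)c2ccc(C)cc2)cc1`: 25000 nM

All three share one core and differ only in the group on the aromatic ring at the end of the double bond. Within the data shown here, in a functional assay on DU-145 cells (Homo sapiens) for inhibition, read by trypan blue exclusion, with a stated time of 96 h (on this read-out higher numbers stand for weaker inhibition of growth and lower numbers for stronger inhibition of growth), compound 2 gives only a limit, > 100000 nM; it is the single compound at the limit of > 100000 nM in this assay, at which 1 of the 3 values shown sits. Compound 4, `CN(C)c1ccc(/C=C(/SCc2ccc(F)cc2)C(=O)c2ccc(Cl)cc2)cc1`, is not yet measured. It keeps the dimethylamino-bearing ring of compound 2 but changes the other side of the double bond: (4-fluorobenzyl)sulfanyl in place of (4-methylphenyl)sulfonyl on a double-bonded chain carbon bound to a carbonyl carbon and a double-bonded chain carbon. Among the measured compounds shown here, no measured step touches this part of the molecule; an at least 100-fold higher number from compound 1 to compound 2 (2.00 log units; beyond the scatter) and an at least 4.0-fold lower number from compound 2 to compound 3 (0.60 log units; beyond the scatter) both vary the ring substituent and mark compound 2 as the weakest of the three, but give no direction for the new change. The estimate for compound 4 is 80000 nM, within 10000 nM to 300000 nM, an expected step of an at least 1.2-fold lower number from compound 2 to compound 4 (0.09 log units; that floor lies within the scatter).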

Compound 4, concentration for 50% growth inhibition: 50000 nM
Beside the measured number, compound 4's estimate is 1.6-fold (0.20 log units) above it, and the stated range covers the measured number.
By their numbers in this assay, from the lowest: compound 1; then compounds 3 and 4 (each within the scatter of the next). At a limit, above all of these: compound 2.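

Among these compounds, this is the first change at the double-bonded chain carbon bound to a carbonyl carbon and a double-bonded chain carbon: in this assay, (4-fluorobenzyl)sulfanyl in place of (4-methylphenyl)sulfonyl gives an at least 2.0-fold lower number from compound 2 to compound 4 (0.30 log units; that floor lies within the scatter). Compound 4 gives a real number, so (4-methylphenyl)sulfonyl is not needed for a measurable result with the dimethylamino group present. The true size of the step stays unknown, because the value of compound 2 is only a limit: the limit of > 100000 nM in this assay, at which 1 of the 4 values shown sits.

A (4-fluorobenzyl)sulfonyl group at this place would help separate the sulfanyl-to-sulfonyl difference from the effect of the 4-fluorobenzyl part. As far as these compounds go, whether the same swap holds with phenoxy on the ring also remains open.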